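The compounds below may be only part of what the source reports. "The series", "measured", "known", "first", "only" and "open" are said of these compounds alone.

Measured compounds:
compound 1 `CCOC(=O)CCCCCOc1cccc(CN(C(=O)c2ccc(-c3cccc(OC(F)(F)F)c3)cc2)C(C)C)c1`: > 26000 nM
compound 2 `CCOC(=O)CCCCCOc1cccc(CN(C(=O)c2ccc(-c3ccc(Cl)c(Cl)c3)cc2)C(C)C)c1`: > 26000 nM
compound 3 `CCOC(=O)CCCCCOc1cccc(CN(C(=O)c2ccc(-c3cccc([N+](=O)[O-])c3)cc2)C(C)C)c1`: > 26000 nM

In an ADME assay on HEK293 cells (Homo sapiens) for cytotoxicity, read by CellTiter-Glo and resazurin assay, with a stated time of 72 h (on this read-out higher numbers stand for an effect only at larger amounts of compound and lower numbers for an effect already at smaller amounts), compound 1 gives > 26000 nM, which is a limit of the assay and not a number. Compound 2 gives > 26000 nM, again a limit. Compound 3 gives > 26000 nM, also a limit. The steps a step that the two limits leave unreadable from compound 1 to compound 2, a step that the two limits leave unreadable from compound 1 to compound 3 and a step that the two limits leave unreadable from compound 2 to compound 3 are accordingly unreadable in size and direction; all three values sit together at the limit of > 26000 nM in this assay, at which 3 of the 3 values shown sit. Compound 3 therefore stands where the other two stand, at the limit, with no readable difference to either.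

Compound 4 `CCOC(=O)CCCCCOc1cccc(CN(C(=O)c2ccc(Br)cc2)C(C)C)c1` differs from compound 3 by bromo in place of 3-nitrophenyl on an aromatic carbon. Going by the values given here, none of the measured steps yields a readable size, so they give no scale for this change; what they do show is that every variation at this position so far has left the read-out at the limit of > 26000 nM in this assay, at which 3 of the 3 values shown sit. On that basis the step that the limit leaves unreadable from compound 3 to compound 4 is expected to be none beyond the scatter. The estimate for compound 4 in this assay is 30000 nM, with a range of 15000 nM to 80000 nM, most likely reported once more as a limit only.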

Compound 4, half-maximal effective concentration: > 26000 nM
Compound 4: only a limit was reported; the forecaster's own chance of this, stated with the estimate: 85%; the middle value is on the limit's open side.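

Compound 4 sits with compound 1, compound 2 and compound 3 at a limit, not a number, so no step among them can be read: the limit of > 26000 nM in this assay, at which 4 of the 4 values shown sit.

The compounds shown leave open the concentration at which any of them would reduce cell viability, and whether the four differ at all.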